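Chlorine moved on the benzyl ring: expected cytotoxicity

The source may report more compounds than this note shows. Statements on the series, on what has been measured and on what is new or still open speak of the compounds shown alone.

Compound 1 `Cc1n[nH]c2c1[C@@H](c1ccc(OCc3cccc(F)c3)cc1)S[C@@H](C)C(=O)N2` gives 103000 nM in an ADME assay on L929 cells (Mus musculus) for cytotoxicity, read by resazurin assay, with a stated time of 96 h; a higher number here means that more compound is tolerated, a lower number that less compound is tolerated. Compound 2 `COc1cc([C@H]2S[C@@H](C)C(=O)Nc3[nH]nc(C)c32)ccc1OCc1ccccc1Cl` carries a methoxy-substituted variant of the shared core, and in this assay compound 2 is recorded as "not determined" (no result reported), so compound 2 has no single number there. Compound 3 `COc1cc([C@H]2S[C@@H](C)C(=O)Nc3[nH]nc(C)c32)ccc1OCc1ccc(Cl)cc1` differs from compound 2 by 4-chlorophenyl in place of 2-chlorophenyl on a saturated chain carbon bound to an oxygen on an aromatic ring. Among the compounds with values here, with no measured pair showing what this change does, the step from compound 2 to compound 3 in this assay is expected to be none beyond the usual scatter, leaning on compound 1 at 103000 nM as the only anchor. Compound 3 is therefore estimated at 80000 nM, within 25000 nM to 250000 nM.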

Compound 3, concentration lethal to 50% of the cells: 50600 nM
Compound 3: middle estimate off by 1.6-fold (0.20 log units), on the high side, within the range that was stated.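

No step can be read between compound 2 and compound 3 in this assay; compound 2 has no single number there. From the compounds shown here alone, what going from 2-chlorobenzyl to 4-chlorobenzyl does in this assay stays open. Nothing available bears on the result of compound 3.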